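The compounds below may be only part of what the source reports. "The series", "measured", "known", "first", "only" and "open" are said of these compounds alone.

Measured compounds:
- Compound 1 `CCCCCCc1cn(C(c2ccccc2)c2cc3cc(Br)ccc3nc2OC)nn1`: in an ADME assay on PANC-1 cells (Homo sapiens) for cytotoxicity, read by sulforhodamine B assay, with a stated time of 48 h, tested at 10 uM (on this read-out lower numbers stand for less inhibition and higher numbers for more inhibition at the one concentration tested (going by the name of the read-out)), compound 1 gives 6.08%
- Compound 2 `COc1nc2ccc(Br)cc2cc1C(c1ccccc1)n1cc(-c2ccccc2)nn1`: in this assay compound 2 gives 30.1%

Among the two measured compounds, compound 2 stands highest in this assay, and its only neighbour is compound 1, which lies a number 24 percentage points higher from compound 1 to compound 2 (beyond the scatter). That single step, a phenyl in place of a hexyl on an aromatic carbon, is the whole of what has been measured so far, and it is modest in size.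

Compound 3 `COc1nc2ccc(Br)cc2cc1C(c1ccccc1)n1cc(-c2ccccc2F)nn1` differs from compound 2 by fluoro in place of hydrogen on an aromatic carbon. Among the measured compounds shown here, no measured step bears on this kind of change: the one step on record swaps a whole chain for a ring, whereas here a single fluorine replaces a hydrogen on the phenyl that compound 2 already carries. With nothing to point either way, the step in this assay is expected to stay within the usual scatter, with no direction favoured. Compound 3 is therefore estimated at 32%, in a range from 15% to 50%, which amounts to an expected step of a number 1.9 percentage points higher from compound 2 to compound 3 (within the scatter).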

Compound 3, a percentage reported as inhibition, at one concentration (the size of the read-out at that concentration, not a potency): 14.7%
Estimate against measurement, compound 3: 17.3 percentage points above; measured number below the stated range.
By their numbers in this assay, from the lowest: compounds 1 and 3 (each within the scatter of the next); then compound 2.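

In this assay, a single fluoro ortho to a large group on the phenyl of compound 2 is enough to matter, with a number 15.4 percentage points lower from compound 2 to compound 3 (beyond the scatter), so this place on the ring responds to even a one-atom change, which the earlier chain-for-ring step could not show. Set against the hexyl of compound 1, the 2-fluorophenyl gives a number 8.6 percentage points higher from compound 1 to compound 3 (within the scatter), so the clear gain seen on going from hexyl to phenyl holds for the unsubstituted phenyl but does not stand clear of the scatter once this fluoro is present. Nothing at hand explains why the fluoro lowers the inhibition at this place.

On these data alone, it remains open whether the loss belongs to fluoro itself or would follow any group in the same place, such as chloro, methyl, methoxy or an amine. Also open, as far as these compounds go, is whether fluoro elsewhere on the phenyl would behave the same way, and whether the same change would hold with a different group in place of the bromo on the shared core.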